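The source may report more compounds than this note shows. Statements on the series, on what has been measured and on what is new or still open speak of the compounds shown alone.

Of the compounds shown here, three have been tested in an assay on HEK293 cells for displacement of a labelled ligand from Neuronal acetylcholine receptor; alpha3/beta4 (Homo sapiens), read by scintillation counting; on this read-out higher numbers stand for weaker inhibition and lower numbers for stronger inhibition. Compound 1 `c1ccc(C2=NOC3(C2)CN2CCC3C2)cc1` gives 16000 nM. Compound 2 `COC1=NOC2(CCCN(C)C2)C1`, which carries a methoxy group on a different core, gives 91000 nM. Compound 3 `BrC1=NOC2(C1)CN1CCC2C1` gives 13000 nM, the lowest of the three numbers, although the gap to compound 1 lies within the scatter and only the gap to compound 2 lies beyond it.

Compound 4 `COC1=NOC2(C1)CN1CCC2C1` has not yet been measured in this assay. It differs from compound 3 by a single exchange: methoxy in place of bromo on a carbon with a double bond to nitrogen. Among the measured compounds shown here, no pair of measured compounds shows this exact exchange on the same core, so its effect has to be judged indirectly. For the measured compounds named here, the only other methoxy-bearing compound, compound 2, has the weakest value in the set, which points toward a higher number for compound 4, but compound 2 also differs in its core, so the step is uncertain.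

For compound 4 a step of a 3.1-fold higher number from compound 3 to compound 4 (0.49 log units; beyond the scatter) toward a weaker value is expected, about the size of the scatter or a little more. The value of compound 4 in this assay is estimated at 40000 nM, with a likely range from 12000 nM to 130000 nM.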

Compound 4, inhibition constant: 46000 nM
Compound 4: the middle estimate sits 1.2-fold (0.06 log units) below what was measured; the measured number falls inside the stated range.
By their numbers in this assay, from the lowest: compounds 3 and 1 (each within the scatter of the next); then compounds 4 and 2 (each within the scatter of the next).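

Among the compounds shown here, on the core shared by compound 3 and compound 4, this is the first direct reading of the exchange of bromo for methoxy on a carbon with a double bond to nitrogen. In this assay, the change gives a modest move toward weaker inhibition (a 3.5-fold higher number from compound 3 to compound 4 (0.55 log units; beyond the scatter)), and this step is beyond the scatter. Methoxy had previously appeared only in compound 2, on a different core, so the effect of the group could not be separated from that of the core; no measurement here explains why this exchange weakens inhibition.

Going by these compounds, it remains open whether an amine or a longer chain such as ethoxy on this carbon would give a lower or higher number than bromo or methoxy. The compounds shown also leave open whether the same exchange would give a similar step on another core.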